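Sulfonyl-aryl substituent change in the acetanilide series

The source may hold more compounds than are shown below. What is called first, only, known or untested is meant among the compounds shown, and "the series" means these compounds.

Compound 1 `CC(=O)c1ccc(NC(=O)CN(C(=O)c2ccccc2)S(=O)(=O)c2ccc(C)cc2)cc1` is the weakest of the three measured compounds: in a functional assay for inhibition, read by spectrophotometry, with a stated time of 20 min, tested at 3 mg/mL (on this read-out lower numbers stand for a weaker effect and higher numbers for a stronger effect at the one concentration tested), compound 1 gives 18.2%. Compound 2 `CCC(C)C(C(=O)Nc1ccc(C(C)=O)cc1)N(C(=O)c1ccccc1)S(=O)(=O)c1ccc(C)cc1` gives 33.4%, and compound 3 `CC(=O)c1ccc(NC(=O)C(C(C)C)N(C(=O)c2ccccc2)S(=O)(=O)c2ccc(C)cc2)cc1` gives 29.7%. The steps of a number 15.2 percentage points higher from compound 1 to compound 2 (beyond the scatter) and a number 11.5 percentage points higher from compound 1 to compound 3 (beyond the scatter) both alter the saturated chain carbon, while a number 3.7 percentage points lower from compound 2 to compound 3 (within the scatter) stays within the scatter.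

Compound 4 `CC(=O)c1ccc(NC(=O)CN(C(=O)c2ccccc2)S(=O)(=O)c2ccc([N+](=O)[O-])cc2)cc1` differs from compound 1 at the sulfonyl aryl ring, the change reading 4-methylphenyl to 4-nitrophenyl (nitro in place of methyl on an aromatic carbon). Within the data shown here, no measured step touches this ring, so nothing bears on the change, and no step beyond the scatter is expected. The expected value for compound 4 is 18%, with a range of 5% to 34%. The expected step is a number 0.2 percentage points lower from compound 1 to compound 4 (within the scatter).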

Compound 4, a percentage reported as inhibition, at one concentration (the size of the read-out at that concentration, not a potency): 20.6%
Estimate against measurement, compound 4: 2.6 percentage points below; low and high end bracket the measured number.
By their numbers in this assay, from the lowest: compounds 1, 4, 3 and 2 (each within the scatter of the next, the first and the last beyond it).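

This position now has its first reading: in this assay the change from 4-methylphenyl to 4-nitrophenyl gives a number 2.4 percentage points higher from compound 1 to compound 4 (within the scatter) and so leaves the number unresolved from that of the methyl parent. Replacing methyl with nitro on this aromatic carbon therefore does not produce a step beyond the scatter on this core, unlike the two chain-carbon substitutions. No evidence bears on this result.

On these data alone, it remains open whether an amine or a carboxylic acid on this aromatic carbon would give a similar reading. Also open, as far as these compounds go, is whether the nitro change would hold with the sec-butyl chain of compound 2 or the isopropyl chain of compound 3.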